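Dimethylamino for pyrrolidinyl on a second core

The source may report more compounds than this note shows. Statements on the series, on what has been measured and on what is new or still open speak of the compounds shown alone.

Measured so far:
compound 1 `CC(C)Oc1cc(-c2ccc(N(C)C)cc2)nc2ccccc12`: 50 nM
compound 2 `CC(C)Oc1cc(-c2ccc(N3CCCC3)cc2)nc2ccccc12`: 500 nM
compound 3 `Cc1cc2oc(-c3ccc(N4CCCC4)cc3)cc(=O)c2cc1C`: > 500 nM (a limit of the assay)

In a functional assay on HT-22 cells (Mus musculus), read by MTT assay, with a stated time of 24 h (on this read-out higher numbers stand for an effect only at larger amounts of compound and lower numbers for an effect already at smaller amounts), compound 1 gives 50 nM and compound 2 gives 500 nM. The change dimethylamino in place of pyrrolidin-1-yl on an aromatic carbon made a 10-fold lower number from compound 2 to compound 1 (1.00 log units; beyond the scatter). For compound 3 this assay reports only a limit, > 500 nM, which is the limit of > 500 nM in this assay, at which 1 of the 3 values shown sits. The difference between the core of compound 3 and that of compound 2 is not broken down here.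

Compound 4 `Cc1cc2oc(-c3ccc(N(C)C)cc3)cc(=O)c2cc1C` is not yet measured. It differs from compound 3 by dimethylamino in place of pyrrolidin-1-yl on an aromatic carbon, the same kind of change as from compound 2 to compound 1. Since compound 3 sits at a limit, the estimate rests on the step of a 10-fold lower number from compound 2 to compound 1 (1.00 log units; beyond the scatter) alone and is uncertain. In this assay compound 4 is expected to give 800 nM, within 100 nM to 5000 nM, an estimated step that the limit leaves unreadable from compound 3 to compound 4.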

Compound 4, half-maximal effective concentration: > 500 nM
Compound 4 ended at the assay's limit; the forecaster's own chance of this, stated with the estimate: 55%; the middle value does not contradict the limit.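

In this assay compound 3 and compound 4 both sit at a limit of the assay, so no step between them can be read: the limit of > 500 nM in this assay, at which 2 of the 4 values shown sit.

The compounds shown leave open whether dimethylamino in place of pyrrolidin-1-yl changes the number at all on the core of compound 3.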